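Alkyne chain extension on the diaminopyrimidine series

The source may report more compounds than this note shows. Statements on the series, on what has been measured and on what is new or still open speak of the compounds shown alone.

Among the compounds with values here, compound 1 `C#Cc1c(C)nc(N)nc1NCCCC` is the weakest of the three compounds measured so far: in an assay on HEK293 cells for agonist activity at Toll-like receptor 8 (Homo sapiens), read by spectrophotometry (on this read-out lower numbers stand for an effect already at smaller amounts and higher numbers for an effect only at larger amounts of compound), compound 1 gives 4900 nM. Compound 2 `CCCCNc1nc(N)nc(C)c1CCCC(C)(C)O` gives 1220 nM in this assay, a lower number by a gap beyond the scatter. Compound 3 `CCCCNc1nc(N)nc(C)c1CCCN1CCN(c2ccccc2)CC1` gives 92 nM in this assay, the lowest number of the set and the furthest from compound 1. Within the data shown here, both compounds 2 and 3 differ from compound 1 in more than one place, so no single-change step between measured compounds is available to lean on.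

Compound 4 `CCCC#Cc1c(C)nc(N)nc1NCCCC` is the next analogue. It differs from compound 1 only in one respect: propyl in place of hydrogen on a triple-bonded carbon. Read one bond further out, ethynyl becomes pent-1-yn-1-yl; the shared core and the butylamino side are untouched.

Among the measured compounds shown here, with no measured single-change step in hand, the expectation rests on the direction seen across the three values: compound 1, carrying the smallest group, gives the highest number, while compounds 2 and 3 give lower numbers. Compound 4 is therefore expected to move in the same direction, with a step of a 2.7-fold lower number from compound 1 to compound 4 (0.43 log units; beyond the scatter) from compound 1 to compound 4 in this assay, modest in size and uncertain. Compound 4 is estimated to give 1800 nM, within a range from 500 nM to 6000 nM.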

Compound 4, half-maximal effective concentration: 5000 nM
Beside the measured number, compound 4's estimate is 2.8-fold (0.44 log units) below it; measured number inside the range.
By their numbers in this assay, from the lowest: compound 3; then compound 2; then compounds 1 and 4 (each within the scatter of the next).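

Propyl in place of hydrogen on a triple-bonded carbon gives a 1.0-fold higher number from compound 1 to compound 4 (0.01 log units; within the scatter) in this assay and this is the only single-change step available in the series so far. It shows that ethynyl and pent-1-yn-1-yl cannot be told apart on this read-out, so extending this position by a plain propyl group, with no ring, no hydrogen-bond donor or acceptor and no net charge, leaves the number within the scatter. No supporting measurement explains why compounds 1 and 4 sit together, so the step stands as an observation only.

The compounds shown leave open whether the flat step holds only for an unadorned chain on the triple-bonded carbon or whether a primary amine or a carboxylic acid at the far end of the pent-1-yn-1-yl chain would separate from compound 1 in this assay by more than the scatter. Going by these compounds, a longer chain such as oct-1-yn-1-yl, or a phenyl group placed directly on the triple-bonded carbon, is equally open, as one step at this position says nothing about the size at which the number might start to move.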